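Working notes: enlarging the amide of compound 2

The compounds below may be only part of what the source reports. "The series", "measured", "known", "first", "only" and "open" are said of these compounds alone.

Measured in a functional assay with Oryctolagus cuniculus as the target; on this read-out lower numbers stand for stronger inhibition and higher numbers for weaker inhibition:
- compound 1 `COc1ccc(-c2nc(N=C(N)N)sc2-c2ccc(OC)cc2)cc1`: 31000 nM
- compound 2 `COc1ccc(-c2nc(CNC(C)=O)sc2-c2ccc(OC)cc2)cc1`: 15 nM

Of these two, compound 2 has the lower number, at 15 nM. The next compound to be measured is compound 3 `COc1ccc(-c2nc(CNC(=O)C3=NNC(=O)CC3)sc2-c2ccc(OC)cc2)cc1`, which keeps the shared core and the amide-type nitrogen. The change is a group of 7 heavy atoms (4 carbon, 2 nitrogen, 1 oxygen; one six-membered non-aromatic ring with 2 hetero atoms) in place of one carbon atom, on a carbonyl carbon: a group with one six-membered non-aromatic ring with 2 hetero atoms replaces the methyl on the carbonyl carbon.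

Among the compounds with values here, only one measured step bears on this: a 2100-fold lower number from compound 1 to compound 2 (3.32 log units; beyond the scatter). It shows that this assay can respond strongly to a change in this substituent, but it involved a different exchange, on an aromatic carbon, so its size does not carry over directly. Within the data shown here, no measured compound has a ring on the carbonyl carbon. Among the measured compounds shown here, with compound 2 at the low end of the numbers so far, a move to a higher number seems more likely, though well short of that single large step. The estimated change is an 8.0-fold higher number from compound 2 to compound 3 (0.90 log units; beyond the scatter). For compound 3 the expected value is 120 nM, with an estimated range from 15 nM to 1500 nM.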

Compound 3, half-maximal inhibitory concentration: 55 nM
Compound 3: the middle estimate sits 2.2-fold (0.34 log units) above what was measured; measured number inside the range.
By their numbers in this assay, from the lowest: compound 2; then compound 3; then compound 1.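

In this assay, the position on the carbonyl carbon accepts far more than the methyl: a 3.7-fold higher number from compound 2 to compound 3 (0.56 log units; beyond the scatter) is only a modest rise, though beyond the scatter, for a group of 7 heavy atoms with one six-membered non-aromatic ring with 2 hetero atoms, 1 hydrogen-bond donor and 2 hydrogen-bond acceptors. The methyl is therefore not a requirement for a low number on this read-out, even though compound 2 keeps the lower number of the pair. Nothing measured here accounts for the rise.

With a single ring-bearing group on this carbonyl carbon, the contributions of its size, its ring and its hetero atoms cannot be separated. An ethyl, a cyclohexyl or a phenyl in the same place would test whether a plain carbon group gives a similar number, while a carboxylic acid or an amine on a longer chain would show how far this position tolerates a charged end group.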